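Exchanging the tert-butyl for a fluorinated aryl group

The source may report more compounds than this note shows. Statements on the series, on what has been measured and on what is new or still open speak of the compounds shown alone.

compound 1 `CC(=O)c1ccc(OCC(=O)Nc2cccc(NC(=O)c3ccc(N(C)C)cc3)c2)cc1F`: 445 nM
compound 2 `CC(C)(C)c1ccc(C(=O)Nc2cccc(NC(=O)COc3ccc4c(=O)ccoc4c3)c2)cc1`: 165 nM

Of the compounds shown here, two have been measured in an assay on isolated protein for inhibition of Rho-associated protein kinase 1 (Homo sapiens), read by scintillation counting, radiometric assay and 33P incorporation, with a stated time of 40 min, in the presence of a further agent that is not named here; on this read-out higher numbers stand for weaker inhibition and lower numbers for stronger inhibition. Compound 1 gives 445 nM, while compound 2 gives 165 nM, the lower of the two numbers; the gap between them lies beyond the usual scatter, so compound 2 stands as the stronger inhibitor of this pair. Compound 3 `Cc1cc(C(=O)Nc2cccc(NC(=O)COc3ccc4c(=O)ccoc4c3)c2)ccc1C(F)(F)F` differs from compound 2 in one place: a group of 11 heavy atoms (8 carbon, 3 fluorine; one six-membered aromatic ring of carbon only) in place of a group of 10 heavy atoms (10 carbon; one six-membered aromatic ring of carbon only), on a carbonyl carbon. Both compounds keep the same shared core and the same amide linkage on the carbonyl carbon; only the aryl group attached there changes. Among the compounds with values here, no measured pair isolates this kind of exchange, so there is no direct precedent for its effect. The step from compound 2 to compound 3 is expected to be small, likely within the scatter, with a slight lean toward a higher number, a 1.5-fold higher number from compound 2 to compound 3 (0.18 log units; within the scatter). Compound 3 is therefore expected to give about 250 nM, with a range from 80 nM to 800 nM.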

Compound 3, half-maximal inhibitory concentration: 460 nM
For compound 3 the middle estimate is 1.8-fold (0.26 log units) below the measured one; low and high end bracket the measured number.
By their numbers in this assay, from the lowest: compound 2; then compounds 1 and 3 (each within the scatter of the next).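

In this assay, replacing the 4-(tert-butyl)phenyl group on the carbonyl carbon with the aryl group carrying fluorine gives a 2.8-fold higher number from compound 2 to compound 3 (0.45 log units; beyond the scatter). This is the first step shown at this place with the rest of the molecule held constant, and it shows that the number responds to the group attached there, with the 4-(tert-butyl)phenyl group giving the stronger inhibition of this pair. Nothing measured here accounts for the size or direction of this step.

With a single exchange at this place, the compounds shown leave open how much of the step belongs to the trifluoromethyl group and how much to the methyl group. They also leave open how this position would respond to an aryl group bearing a nitrile or a carboxylic acid.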